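The source may hold more compounds than are shown below. What is called first, only, known or untested is meant among the compounds shown, and "the series" means these compounds.

Of the compounds shown here, two of a shared core have been tested in a functional assay on UACC-62 cells (Homo sapiens) for cytotoxicity, read by sulforhodamine B assay, with a stated time of 48 h, tested at 100 nM; on this read-out higher numbers stand for a weaker effect at the one concentration tested and lower numbers for a stronger effect. Compound 1 `COc1cc(C)cc(-c2nn(CC#N)cc2-c2ccc(-c3cccc(C(C)=O)c3)nc2)c1` gives 71% in this assay. Compound 2 `Cc1cc(O)cc(-c2nn(CC#N)cc2-c2ccnc(-c3ccc(Oc4ccccc4)cc3)c2)c1` gives 84% in this assay, the higher of the two numbers; the gap to compound 1 lies beyond the scatter, so compound 2 shows the weaker effect of the pair at the one concentration tested. The two compounds differ in more than one place, and no single change between them has been measured, so their numbers only set the span seen so far.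

Compound 3 `Cc1cc(O)cc(-c2nn(CC#N)cc2-c2ccnc(-c3ccc(N(C)C)cc3)c2)c1` has not yet been measured in this assay. It is made from compound 2 by one change: dimethylamino in place of phenoxy on an aromatic carbon. Within the data shown here, no measured step covers a change of this kind, so the expectation for compound 3 rests on the number of compound 2 alone. The step from compound 2 to compound 3 in this assay is expected to be a number 4 percentage points lower from compound 2 to compound 3 (within the scatter), that is, no step beyond the scatter in either direction. For compound 3 the estimated value in this assay is 80%, with a range from 60% to 100%.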

Compound 3, a percentage reported as activity, at one concentration (the size of the read-out at that concentration, not a potency): 87%
For compound 3 the middle estimate is 7 percentage points below the measured one, and the stated range covers the measured number.
By their numbers in this assay, from the lowest: compound 1; then compounds 2 and 3 (each within the scatter of the next).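

In this assay, putting dimethylamino in place of phenoxy on an aromatic carbon, para to a large group, gives a number 3 percentage points higher from compound 2 to compound 3 (within the scatter) and so provides the first single change measured in this series. At this place, and for this pair only, a group of 3 heavy atoms with no ring stands in for one of 7 heavy atoms with a six-membered aromatic ring of carbon only, and the read-out at the one concentration tested does not separate the two compounds, so the aromatic ring of phenoxy is not required to keep the number in this range. The data shown offer no measurement that would explain this outcome.

Among these compounds, the pair covers only two groups at this place, both with 1 hydrogen-bond acceptor and no hydrogen-bond donor, so it remains open whether a primary amine or a carboxylic acid there would give a step beyond the scatter. On these data alone, with a single concentration as the read-out, it also remains open whether compound 2 and compound 3 would stay within the scatter of each other at other concentrations.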